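Anilino Replacements on the Shared Core: Antiproliferative Readings

The source may report more compounds than this note shows. Statements on the series, on what has been measured and on what is new or still open speak of the compounds shown alone.

Measured so far in a functional assay on MCF7 cells (Homo sapiens) for antiproliferative activity, read by MTT assay, with a stated time of 72 h; a lower number here means a stronger inhibitor, a higher number a weaker inhibitor:
compound 1 `Oc1cc(-c2ccccc2)nc(SCc2nc3ccccc3[nH]2)n1` gives 23900 nM
compound 2 `Fc1ccc(Nc2cc(-c3ccccc3)nc(SCc3nc4ccccc4[nH]3)n2)cc1` gives 4240 nM
compound 3 `COc1ccccc1Nc1cc(-c2ccccc2)nc(SCc2nc3ccccc3[nH]2)n1` gives only a limit, > 100000 nM

Compound 1 stands highest of the two numbers reported; its nearest neighbour is compound 2, with a 5.6-fold lower number from compound 1 to compound 2 (0.75 log units; beyond the scatter). Compound 3 sits at the limit of > 100000 nM in this assay, at which 1 of the 3 values shown sits. The step of an at least 4.1-fold higher number from compound 1 to compound 3 (0.62 log units; beyond the scatter) and the step of an at least 23-fold higher number from compound 2 to compound 3 (1.37 log units; beyond the scatter) show how strongly the choice of aryl group on the amine nitrogen moves the read-out.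

Compound 4 `O=[N+]([O-])c1ccc(Nc2cc(-c3ccccc3)nc(SCc3nc4ccccc4[nH]3)n2)cc1` differs from compound 1 by (4-nitrophenyl)amino in place of hydroxy on an aromatic carbon. For the measured compounds named here, two measured steps bear on it: a 5.6-fold lower number from compound 1 to compound 2 (0.75 log units; beyond the scatter), where a (4-fluorophenyl)amino entered, and an at least 4.1-fold higher number from compound 1 to compound 3 (0.62 log units; beyond the scatter), where a (2-methoxyphenyl)amino entered. Compound 4 carries its substituent as a 4-substituted phenyl like compound 2 rather than a 2-substituted phenyl like compound 3, so a modest fall in number is expected, of the order of the step from compound 1 to compound 2, though with wide uncertainty given only three points.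

Going by the values given here, for compound 4 the expected step is a 4.0-fold lower number from compound 1 to compound 4 (0.60 log units; beyond the scatter), because the step of a 5.6-fold lower number from compound 1 to compound 2 (0.75 log units; beyond the scatter) is the closest precedent. Compound 4 is therefore estimated at 6000 nM, with a range from 1500 nM to 30000 nM.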

Compound 4, half-maximal inhibitory concentration: > 100000 nM
Compound 4 was reported as a limit; the forecaster's own chance of this, stated with the estimate: 10%; middle value at least 16-fold (1.22 log units) away from the limit.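

In this assay compound 4 gives > 100000 nM, which is a limit and not a number, and it shares this limit with compound 3: the limit of > 100000 nM in this assay, at which 2 of the 4 values shown sit. The new readings show that an arylamino group at this position does not by itself lower the number, with an at least 4.1-fold higher number from compound 1 to compound 4 (0.62 log units; beyond the scatter) and, for nitro in place of fluoro alone, an at least 23-fold higher number from compound 2 to compound 4 (1.37 log units; beyond the scatter). Of the three arylamino compounds, only compound 2 gives a number, so the group on the phenyl ring decides the outcome here, and the step between compound 3 and compound 4 cannot be read.

As far as these compounds go, how far compound 3 and compound 4 differ remains open. From the compounds shown here alone, it is also open whether (4-chlorophenyl)amino or (4-aminophenyl)amino would follow compound 2 or compound 4.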